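The source may hold more compounds than are shown below. What is called first, only, known or untested is meant among the compounds shown, and "the series" means these compounds.

Measured so far:
compound 1 `Cc1ccc(SCc2ccc(/C=C/C(=O)Nc3ccccc3N)cc2)cc1` — 4.93%
compound 2 `Nc1ccccc1NC(=O)c1ccc(CSc2nccc(C(F)(F)F)n2)cc1` — 93.1%
compound 3 `Nc1ccccc1NC(=O)c1ccc(CSc2cccc(F)c2)cc1` — 81.4%

In a functional assay on HCT-116 cells (Homo sapiens) for inhibition, read by CCK-8 assay, with a stated time of 72 h, tested at 8 uM (on this read-out lower numbers stand for less inhibition of growth and higher numbers for more inhibition of growth at the one concentration tested), compound 1 gives 4.93%, the lowest of the three numbers. Its nearest neighbour is compound 3 with 81.4%, a number higher by a margin beyond the scatter. The furthest is compound 2 with 93.1%, also beyond the scatter. Compounds 2 and 3 share neither the cinnamide link nor the thioether partner of compound 1, so their two values show only where the series can reach, not what a change on the thioether side does.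

Compound 4 `CC(C)(C)c1ccc(SCc2ccc(/C=C/C(=O)Nc3ccccc3N)cc2)cc1` differs from compound 1 in one place: tert-butyl in place of methyl on an aromatic carbon. Going by the values given here, no measured pair in this set carries that change, so the size of the step rests on the structural change alone. The expected step in this assay is small, upward at most, or none beyond the scatter.

For compound 4 the expected value is 12%, with a range from 0% to 35%. The expected step of a number 7.1 percentage points higher from compound 1 to compound 4 (within the scatter) is estimated to stay within the usual scatter.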

Compound 4, percent growth inhibition at one concentration: 39%
Compound 4: the middle estimate sits 27 percentage points below what was measured, outside the stated range (above it).
By their numbers in this assay, from the lowest: compound 1; then compound 4; then compound 3; then compound 2.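

In this assay, tert-butyl in place of methyl on the aromatic ring gives a number 34.1 percentage points higher from compound 1 to compound 4 (beyond the scatter), the first direct sign that this position on the core of compound 1 affects the read-out. Compounds 2 and 3 could not show this, as neither shares that core or carries either group. The finding rests on this single pair, and nothing on hand accounts for the size of the step.

Two alkyl groups cannot show whether the number keeps rising with group size, so ethyl or isopropyl at the same position would help to settle the trend. An amine or a carboxylic acid there would show whether the gain is confined to alkyl groups, and compounds 2 and 3 differ from compound 4 in too many places to answer this.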